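A Fused Bicycle Replaces the Pyridine at the Exocyclic Carbon

The source may hold more compounds than are shown below. What is called first, only, known or untested is meant among the compounds shown, and "the series" means these compounds.

Of the compounds shown here, three sharing one core have been measured in a functional assay on JAR cells (Homo sapiens) for inhibition, read by MTT assay, with a stated time of 72 h, tested at 10 uM; a lower number here means less inhibition, a higher number more inhibition at the concentration tested (going by the name of the read-out). Compound 1 `CCOC(=O)C1=C(Nc2ccccc2)S/C(=C\c2ccccc2)C1=O` gives 20.3%. Compound 2 `CCOC(=O)C1=C(Nc2ccccc2)S/C(=C\c2ccc(OC)cc2)C1=O`, which carries a methoxy in place of hydrogen on an aromatic carbon, gives 32.9%, a rise of a number 12.6 percentage points higher from compound 1 to compound 2 (beyond the scatter). Compound 3 `CCOC(=O)C1=C(Nc2ccccc2)S/C(=C\c2cccnc2)C1=O` gives 32.1%; the change from phenyl to pyridin-3-yl on the double-bonded chain carbon brought a number 11.8 percentage points higher from compound 1 to compound 3 (beyond the scatter), while compound 2 and compound 3 lie within the scatter of each other, a number 0.8 percentage points lower from compound 2 to compound 3 (within the scatter). Compound 3 thus stands second highest of the three, close to compound 2 and clearly above compound 1.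

Compound 4 `CCOC(=O)C1=C(Nc2ccccc2)S/C(=C\c2cc3ccncc3[nH]2)C1=O` differs from compound 3 by a group of 9 heavy atoms (7 carbon, 2 nitrogen; one five-membered aromatic ring with 1 hetero atom, one six-membered aromatic ring with 1 hetero atom) in place of a group of 6 heavy atoms (5 carbon, 1 nitrogen; one six-membered aromatic ring with 1 hetero atom), on a double-bonded chain carbon bound to a double-bonded ring carbon. For the measured compounds named here, no measured step covers a fused two-ring group at that position; the steps from compound 1 show that changing the aryl group there moved the read-out only modestly, and the step between the two heteroaryl-bearing analogues was within the scatter. The account therefore expects no shift beyond the scatter, a number 1.9 percentage points higher from compound 3 to compound 4 (within the scatter), and estimates compound 4 at 34%, within 18% to 52%.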

Compound 4, a percentage reported as inhibition, at one concentration (the size of the read-out at that concentration, not a potency): 26.3%
The estimate for compound 4 lay 7.7 percentage points above the measured number; low and high end bracket the measured number.
By their numbers in this assay, from the lowest: compounds 1, 4, 3 and 2 (each within the scatter of the next, the first and the last beyond it).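

In this assay, the fused two-ring group on the double-bonded chain carbon cannot be told apart from any of the three earlier aryl groups (a number 5.8 percentage points lower from compound 3 to compound 4 (within the scatter); a number 6.6 percentage points lower from compound 2 to compound 4 (within the scatter); a number 6 percentage points higher from compound 1 to compound 4 (within the scatter)). The earlier compounds shown here showed only single-ring groups at this carbon, and the steps to compound 2 and compound 3 from compound 1 lay beyond the scatter, whereas the step to compound 4 from compound 1 does not, so this larger group, with its hydrogen-bond donor, gives no readable gain over phenyl and no readable change from pyridin-3-yl or 4-methoxyphenyl. Nothing available here bears on why this is so.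

The compounds shown leave open how a non-aromatic group such as morpholine or a dimethylamino-bearing chain would read at this carbon. They also leave open whether a carboxylic acid in place of the ethyl ester would move the number at all.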